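A few compounds are considered here, and "the series" means these few. Any claim that something is new, unique, unknown or untested is made for them only; others in the source may bear on it.

Measured so far:
compound 1 `c1ccc2c(c1)CCC2NC1CCN(CCCc2c[nH]c3ccc(-n4cnnc4)cc23)CC1` — 280 nM
compound 2 `C[C@@H](NC1CCN(CCCc2c[nH]c3ccc(-n4ccnc4)cc23)CC1)c1ccccc1` — 110 nM

In an assay on CHO cells for displacement of a labelled ligand from 5-hydroxytryptamine receptor 1B (Homo sapiens) (a higher number here means a weaker inhibitor, a lower number a stronger inhibitor), compound 1 gives 280 nM, the higher of the two numbers, so the weaker inhibitor of the pair. Compound 2 gives 110 nM; the gap between these two values lies beyond the scatter, but no single-point comparison connects the two structures, so only the values themselves are set side by side.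

Compound 3 `c1cncc(CNC2CCN(CCCc3c[nH]c4ccc(-n5cnnc5)cc34)CC2)c1` has not been measured. It differs from compound 1 in one place: (pyridin-3-yl)methyl in place of 2,3-dihydro-1H-inden-1-yl on an amine nitrogen. Nothing measured in this series speaks to this exchange, so the expectation rests on compound 1 alone. A small step toward a higher number, at or a little beyond the scatter, is expected: a 1.6-fold higher number from compound 1 to compound 3 (0.21 log units; within the scatter). For compound 3 the estimated value in this assay is 450 nM, with a likely range from 150 nM to 1300 nM.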

Compound 3, half-maximal inhibitory concentration: 140 nM
Beside the measured number, compound 3's estimate is 3.2-fold (0.51 log units) above it; the measured number lies below the stated range.
By their numbers in this assay, from the lowest: compounds 2, 3 and 1 (each within the scatter of the next, the first and the last beyond it).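

For the compounds shown here, on the amine nitrogen, (pyridin-3-yl)methyl in place of 2,3-dihydro-1H-inden-1-yl gives a 2.0-fold lower number from compound 1 to compound 3 (0.30 log units; within the scatter) in this assay, the first reading of a single change. This position therefore accepts the loss of the five-membered non-aromatic ring and the entry of a ring nitrogen with one hydrogen-bond acceptor, with no difference that this assay can resolve. No supporting measurement bears on what lies behind this result.

On these data alone, a benzyl group on the same amine nitrogen would separate the effect of the ring nitrogen from that of the change in ring system, and the pyridin-2-ylmethyl and pyridin-4-ylmethyl groups remain open as well. Compound 2 differs from compound 1 and compound 3 in more than one place, so it cannot settle these questions.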